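The source may report more compounds than this note shows. Statements on the series, on what has been measured and on what is new or still open speak of the compounds shown alone.

In a functional assay on the whole organism for inhibition, with Mus musculus as the target, at a dose of 10 mg/kg by the oral route (a lower number here means less inhibition, a higher number more inhibition at the dose given (going by the name of the read-out)), the measured compounds read:
compound 1 `COc1ccc(N(C)/C(S)=C2/C(=O)c3cc(Cl)ccc3N(C)C2=O)cc1` gives 45%
compound 2 `CN1C(=O)/C(=C(/S)N(C)c2ccc(Cl)cc2)C(=O)c2cc(Cl)ccc21` gives 47%

Going by the values given here, compound 2 and compound 1 sit within the scatter of each other, the one measured step being a number 2 percentage points higher from compound 1 to compound 2 (within the scatter).

Compound 3 `CN1C(=O)/C(=C(/S)N(C)c2ccc(Br)cc2)C(=O)c2cc(Cl)ccc21` differs from compound 2 by bromo in place of chloro on an aromatic carbon. Among the compounds with values here, no measured step exchanges one halogen for another; the only step known, a number 2 percentage points higher from compound 1 to compound 2 (within the scatter), changes a different group and was itself within the scatter. No step beyond the scatter is therefore expected, no change at the digits printed from compound 2 to compound 3 (within the scatter). For compound 3 the estimate is 47%, with a range of 37% to 57%.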

Compound 3, a percentage reported as inhibition, in the whole organism at one dose (the size of the read-out at that dose, not a potency): 50%
The estimate for compound 3 lay 3 percentage points below the measured number; low and high end bracket the measured number.
By their numbers in this assay, from the lowest: compounds 1, 2 and 3 (each within the scatter of the next).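

In this assay, going by these compounds alone, the exchange of 4-chlorophenyl for 4-bromophenyl gives a number 3 percentage points higher from compound 2 to compound 3 (within the scatter), the only halogen-for-halogen step here, while bromo in place of methoxy gives a number 5 percentage points higher from compound 1 to compound 3 (within the scatter). Chloro, bromo and methoxy at this position therefore cannot be told apart at this dose. No measured data bear on why these groups read alike.

As far as these compounds go, whether any group at this position can shift the read-out beyond the scatter remains open. An amine or a carboxylic acid here would test this, and the effect of changes elsewhere on the shared core is also unknown.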